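The source may hold more compounds than are shown below. What is called first, only, known or untested is meant among the compounds shown, and "the series" means these compounds.

Two close relatives of the same core have been tested in an ADME assay on HaCaT cells (Homo sapiens) for cytotoxicity, read by MTT assay, with a stated time of 72 h; a higher number here means a weaker inhibitor, a lower number a stronger inhibitor. Compound 1 `COc1ccc(Nc2nnnn2-c2cccc(Br)c2)cc1` gives 107000 nM in this assay, and compound 2 `COc1ccc(-n2nnnc2Nc2ccccc2Br)cc1` gives 137000 nM, so the two numbers sit within the usual scatter of each other, with no ordering between them. Compound 3 `COc1ccc(Nc2nnnn2-c2cccc(F)c2)cc1` has not yet been measured. It differs from compound 1 by fluoro in place of bromo on an aromatic carbon. Among the compounds with values here, with no measured step of this kind to lean on, the expected change from compound 1 to compound 3 in this assay is a 1.2-fold higher number from compound 1 to compound 3 (0.08 log units; within the scatter), essentially none beyond the scatter. Compound 3 is therefore estimated at 130000 nM, within 60000 nM to 300000 nM.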

Compound 3, half-maximal inhibitory concentration: 101000 nM
For compound 3 the middle estimate is 1.3-fold (0.11 log units) above the measured one; the range from low to high includes it.
By their numbers in this assay, from the lowest: compounds 3, 1 and 2 (each within the scatter of the next).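

Putting fluoro in place of bromo on this aromatic carbon, meta to a large group, gives a 1.1-fold lower number from compound 1 to compound 3 (0.03 log units; within the scatter) in this assay and so leaves the number unchanged beyond the usual scatter. At this position, the two halogens cannot be told apart in this cytotoxicity read-out. Nothing measured here offers an explanation for this result.

Still open, on these data alone, is whether a different kind of group at this position, such as an amine or a carboxylic acid, would shift the number beyond the scatter. Also open, as far as these compounds go, is whether the same swap would behave alike elsewhere on the ring.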